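The source may report more compounds than this note shows. Statements on the series, on what has been measured and on what is new or still open speak of the compounds shown alone.

Measured compounds:
Compound 1 `CCCC(=O)c1ccc(OCCCCOc2cc(C(=O)O)ccc2OC)c(C)c1O` gives 64.2% in an assay on HEK293 cells for positive allosteric modulation of metabotropic glutamate receptor 3 (Rattus norvegicus), read by thallium flux, with a stated time of 2.5 min; on this read-out higher numbers stand for larger maximal responses and lower numbers for smaller maximal responses.
Compound 2 `COc1ccc(C(=O)O)cc1OCCCCOc1ccc(C(=O)C(C)C)c(O)c1C` gives 59.9% in this assay.
Compound 3 `CCCC(=O)c1ccc(OCCCCOc2ccc(C(=O)O)cc2C)c(C)c1O` gives 40.5% in this assay.

Compound 1 and compound 2 differ in one place only: isopropyl in place of propyl on a carbonyl carbon. That change produced a number 4.3 percentage points lower from compound 1 to compound 2 (within the scatter). Compound 3 stands on a different core; the difference between the core of compound 3 and the core of compound 1 is not broken down here, and its value is the lowest of the three.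

Compound 4 `Cc1cc(C(=O)O)ccc1OCCCCOc1ccc(C(=O)C(C)C)c(O)c1C` has not been measured. It stands to compound 3 as compound 2 stands to compound 1, with the same change at a place described in the same words: isopropyl in place of propyl on a carbonyl carbon. Because the earlier step was a number 4.3 percentage points lower from compound 1 to compound 2 (within the scatter), a step of similar size is expected from compound 3 to compound 4, namely a number 3.5 percentage points lower from compound 3 to compound 4 (within the scatter). Compound 4 is therefore estimated at 37% in this assay, expected to fall between 25% and 50%.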

Compound 4, largest response reached (reported as percent of maximum), in percent of the reference or control that the assay uses: 25.2%
Beside the measured number, compound 4's estimate is 11.8 percentage points above it; the range from low to high includes it.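

On the core of compound 3, isopropyl in place of propyl on a carbonyl carbon gave a number 15.3 percentage points lower from compound 3 to compound 4 (beyond the scatter) in this assay. Set beside the earlier step, this result does not separate the two cores: the same change on two cores in this assay, a number 4.3 percentage points lower (within the scatter) from compound 1 to compound 2 and a number 15.3 percentage points lower (beyond the scatter) from compound 3 to compound 4, 11 percentage points apart, within the scatter of two such steps. The two pairs are therefore compatible with the change carrying over between these cores, but they do not fix the size of the step, and they show nothing about cores beyond these two.

Going by these compounds, it remains open whether an ethyl or a cyclopropyl group on the same carbonyl carbon would fit these steps. On these data alone, it is also open how the change would read on a core carrying an amide in place of the carboxylic acid.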